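The compounds below may be only part of what the source reports. "The series", "measured", "known", "first", "only" and "open" are said of these compounds alone.

Measured compounds:
- Compound 1 `COc1cccc(NC(=S)NC2CC(C)(C)Oc3ccc(Br)cc32)c1`, a functional assay on U-373MG ATCC cells (Homo sapiens) for inhibition, read by MTT assay, with a stated time of 72 h; on this read-out lower numbers stand for stronger inhibition and higher numbers for weaker inhibition: 66000 nM
- Compound 2 `CC1(C)CC(NC(=O)NCc2ccccc2)c2cc(Br)ccc2O1`, this assay: 27000 nM
- Compound 3 `O=[N+]([O-])c1cccc(NC(=S)NCc2cccc(Cl)c2)c1`, this assay: 32000 nM

All three measured compounds give high numbers in this assay, so none inhibits strongly. Compound 1 stands at the highest number of the three; compound 3 comes nearest with a lower number that lies beyond the usual scatter, and compound 2 lies furthest, also beyond the scatter. Compound 1 is thus the weakest of the measured set. For the measured compounds named here, no pair of measured compounds differs in one place only, so no step of known size is available.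

The next compound, compound 4 `CC1(C)CC(NC(=S)Nc2ccc(Cl)cc2)c2cc(Br)ccc2O1`, shares the core of compound 1 and differs from it in one place: 4-chlorophenyl in place of 3-methoxyphenyl on an amide-type nitrogen. Going by the values given here, the measured compounds offer no close precedent for this change. Compound 3 carries a chlorine on one aromatic ring and a nitro group on the other and gives 32000 nM, but it lacks the core of compound 1, so nothing of its number can be carried over directly.

The expectation is a small step in this assay, toward a somewhat lower number than compound 1, with wide uncertainty and no firm direction. For compound 4 the estimate is 40000 nM, in the range 15000 nM to 100000 nM, which as a step from compound 1 to compound 4 means a 1.7-fold lower number from compound 1 to compound 4 (0.22 log units; within the scatter).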

Compound 4, half-maximal inhibitory concentration: 7000 nM
The estimate for compound 4 lay 5.7-fold (0.76 log units) above the measured number, outside the stated range (below it).
By their numbers in this assay, from the lowest: compound 4; then compounds 2 and 3 (each within the scatter of the next); then compound 1.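

For the compounds shown here, on the amide-type nitrogen whose other neighbour is the thiocarbonyl carbon, the aryl group is a position that responds: with the core of compound 1 held fixed, 4-chlorophenyl in place of 3-methoxyphenyl in this assay gives a 9.4-fold lower number from compound 1 to compound 4 (0.97 log units; beyond the scatter) and supplies the first step of known size. The phenyl ring stays through this change, while the ring substituent and its location both differ, so the step belongs to the two-part change as a whole and cannot be assigned to the chlorine or to its location alone. Nothing available here accounts for the size or direction of the step.

Still open, from the compounds shown here alone, is how the two parts of the change divide, which 3-chlorophenyl and 4-methoxyphenyl on the same nitrogen would help to separate. Also open, going by these compounds, is how far this position tolerates other groups, such as 4-aminophenyl, 4-carboxyphenyl or a longer chain like 4-chlorophenethyl, and whether the step carries over when a carbonyl replaces the thiocarbonyl.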